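Stereoisomeric hydroxylated piperidine acids against a cytosolic glycosidase

The source may report more compounds than this note shows. Statements on the series, on what has been measured and on what is new or still open speak of the compounds shown alone.

Measured compounds:
Compound 1, `O=C(O)[C@H]1NC[C@@H](O)[C@H](O)[C@H]1O`: 6.3%
Compound 2, `O=C(O)[C@H]1NC[C@H](O)[C@H](O)[C@@H]1O`: 26%
Compound 3, `O=C(O)[C@H]1NC[C@H](O)[C@@H](O)[C@@H]1O`: 43%

Three stereoisomers sharing one core were tested in an assay on isolated protein for inhibition of cytosolic endo-beta-N-acetylglucosaminidase (Homo sapiens), tested at 1000 uM; on this read-out lower numbers stand for less inhibition and higher numbers for more inhibition at the one concentration tested (going by the name of the read-out). Compound 1 gives 6.3%, compound 2 gives 26% and compound 3 gives 43%. Compound 2 stands second highest of the three numbers; its nearest neighbour is compound 3, and compound 1 lies furthest from it.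

The steps among these compounds arise from configuration alone, as the evidence shows (the fact that compounds 1 and 2 differ only in the configuration as drawn), the fact that compounds 1 and 3 differ only in the configuration as drawn and (the fact that compounds 2 and 3 differ only in the configuration as drawn). The change is a number 19.7 percentage points higher from compound 1 to compound 2 (beyond the scatter), a number 36.7 percentage points higher from compound 1 to compound 3 (beyond the scatter) and a number 17 percentage points higher from compound 2 to compound 3 (beyond the scatter). Every inversion recorded so far moved this assay beyond the scatter, by modest to large amounts.

Compound 4, `O=C(O)[C@@H]1NC[C@@H](O)[C@H](O)[C@@H]1O`, has not yet been measured. Relative to compound 2 the difference is the two compounds have the same atoms and bonds and differ only in configuration as drawn: 2 of 4 stereo elements differ; a stereocentre at a saturated ring carbon is drawn S in compound 2 and R in compound 4; a stereocentre at a saturated ring carbon is drawn S in compound 2 and R in compound 4. Among the compounds with values here, neither of these two inverted centres is the one that separates compound 2 from compound 3, so the measured steps bear on it only in showing that configuration changes of this kind shift this assay appreciably, in either direction. A step beyond the scatter is therefore expected, but its direction is uncertain. Compound 4 is estimated at 25%, within 5% to 55%, corresponding to an expected step of a number 1 percentage points lower from compound 2 to compound 4 (within the scatter).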

Compound 4, a percentage reported as inhibition, at one concentration (the size of the read-out at that concentration, not a potency): 0.8%
The estimate for compound 4 lay 24.2 percentage points above the measured number; the measured number lies below the stated range.
By their numbers in this assay, from the lowest: compounds 4 and 1 (each within the scatter of the next); then compound 2; then compound 3.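

In this assay, within the data shown here, compound 4 settles the direction for this pair of inverted stereocentres, which the earlier compounds left undecided: the change is a number 25.2 percentage points lower from compound 2 to compound 4 (beyond the scatter), so this configuration goes with much less inhibition than that of compound 2. The change is a number 42.2 percentage points lower from compound 3 to compound 4 (beyond the scatter) when measured against the highest number in the series, where three stereocentres differ. Among these compounds, the change is a number 5.5 percentage points lower from compound 1 to compound 4 (within the scatter), the first step that stays inside the scatter, so compounds 1 and 4 cannot be told apart and a change of two stereocentres need not shift the read-out: the fact that compounds 1 and 4 differ only in the configuration as drawn.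

With both stereocentres differing at once, the compounds shown do not tell whether one of them alone carries the loss seen for compound 4, and all the numbers come from a single concentration, so they give no potency. They also leave open whether this dependence on configuration would survive replacing the carboxylic acid with a methyl ester or a primary amide, or adding a longer chain to the ring nitrogen of the shared core.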